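Pyrazole amides at rat mGlu5: para-chloro analogue

A few compounds are considered here, and "the series" means these few. Any claim that something is new, unique, unknown or untested is made for them only; others in the source may bear on it.

Measured so far:
Compound 1 `O=C(Nc1cc(-c2ccccc2)nn1-c1ccccc1)c1ccc(F)cc1` — 50 nM
Compound 2 `O=C(Nc1cc(-c2ccccc2)nn1-c1ccccc1)c1ccccc1F` — 100 nM

In an assay on isolated protein with metabotropic glutamate receptor 5 (Rattus norvegicus) as the target (a higher number here means that more compound is needed for the effect, a lower number that less compound is needed), compound 2 gives the higher of the two numbers; its nearest neighbour is compound 1, and the step of a 2.0-fold higher number from compound 1 to compound 2 (0.30 log units; within the scatter) lies within the scatter. Compound 3 `O=C(Nc1cc(-c2ccccc2)nn1-c1ccccc1)c1ccc(Cl)cc1` carries the change (4-chlorophenyl in place of 2-fluorophenyl on a carbonyl carbon). Among the measured compounds shown here, only that one measured step bears on it, and it was small; the para-position benzoyl of compound 1 is the closer comparator. Compound 3 is therefore expected to give a step of a 2.5-fold lower number from compound 2 to compound 3 (0.40 log units; beyond the scatter), a number near that of compound 1 or modestly lower. Compound 3 is estimated at 40 nM, with a range of 12 nM to 130 nM.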

Compound 3, half-maximal effective concentration: 100 nM
For compound 3 the middle estimate is 2.5-fold (0.40 log units) below the measured one; the range from low to high includes it.
By their numbers in this assay, from the lowest: compounds 1, 2 and 3 (each within the scatter of the next).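

In this assay, 4-chlorophenyl in place of 2-fluorophenyl on the carbonyl carbon gives no change at the digits printed from compound 2 to compound 3 (within the scatter), and chloro in place of fluoro on the aromatic carbon gives a 2.0-fold higher number from compound 1 to compound 3 (0.30 log units; within the scatter). Both steps lie within the scatter, so among these three compounds neither swapping the halogen nor the change of aryl group separates the numbers. No available data offer an explanation for this result.

Still open, from the compounds shown here alone, is whether 2-chlorophenyl reads like 4-chlorophenyl. Also open, going by these compounds, is whether an amine or a carboxylic acid on this phenyl ring would give a step beyond the scatter.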